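This account rests on a few compounds, and the source may have more. Where it says the series, first, only, none or still open, it means among the compounds named here.

Compound 1 `COc1ccc(C2C(C#N)=C(N)N(c3cc(OC)c(OC)c(OC)c3)C3=C2C(=O)CC(C)(C)C3)cc1`: 11%
Compound 2 `COc1cc(N2C(N)=C(C#N)C(c3ccc(OC)c4ccccc34)C3=C2CC(C)(C)CC3=O)cc(OC)c1OC`: 40%
Compound 3 `COc1ccccc1C1C(C#N)=C(N)N(c2cc(OC)c(OC)c(OC)c2)C2=C1C(=O)CC(C)(C)C2`: 70%

In a functional assay on Ehrlich cells (Mus musculus) for cytotoxicity, tested at 50 ug/mL (a lower number here means a weaker effect, a higher number a stronger effect of the compound at the concentration tested), compound 3 gives the highest of the three numbers; the nearest of the others stands a number 30 percentage points higher from compound 2 to compound 3 (beyond the scatter) and the furthest a number 59 percentage points higher from compound 1 to compound 3 (beyond the scatter). Compound 4 `COc1cc(N2C(N)=C(C#N)C(c3ccc(C)o3)C3=C2CC(C)(C)CC3=O)cc(OC)c1OC` differs from compound 3 in one place: 5-methylfuran-2-yl in place of 2-methoxyphenyl on a saturated ring carbon. Every measured step here swaps the group on that same saturated ring carbon, and each moved the read-out beyond the scatter: a number 29 percentage points higher from compound 1 to compound 2 (beyond the scatter), a number 59 percentage points higher from compound 1 to compound 3 (beyond the scatter) and a number 30 percentage points higher from compound 2 to compound 3 (beyond the scatter). None of them involves 5-methylfuran-2-yl, so the direction of this change cannot be read from them. Because compound 3 sits at the top with 70%, the number for compound 4 is expected to drop, a number 30 percentage points lower from compound 3 to compound 4 (beyond the scatter). The estimate for compound 4 is 40%, between 10% and 75%.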

Compound 4, a percentage reported as activity, at one concentration (the size of the read-out at that concentration, not a potency): 41%
Compound 4: middle estimate off by 1 percentage points, on the low side, and the stated range covers the measured number.
By their numbers in this assay, from the lowest: compound 1; then compounds 2 and 4 (each within the scatter of the next); then compound 3.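

In this assay, the five-membered 5-methylfuran-2-yl ring at this saturated ring carbon beats 4-methoxyphenyl (a number 30 percentage points higher from compound 1 to compound 4 (beyond the scatter)) but falls short of 2-methoxyphenyl (a number 29 percentage points lower from compound 3 to compound 4 (beyond the scatter)). It cannot be separated from the much different 4-methoxynaphthalen-1-yl group (a number 1 percentage points higher from compound 2 to compound 4 (within the scatter)), so two unlike rings can give matching read-outs here. Nothing available explains these differences. Still open, as far as these compounds go, is whether the methyl on the 5-methylfuran-2-yl ring matters, and how a non-aromatic group such as cyclohexyl, or a phenyl ring carrying an amine, would behave at this carbon.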